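Swapping the difluorophenyl for thiophene in an H1 antagonist

The compounds below may be only part of what the source reports. "The series", "measured", "known", "first", "only" and "open" are said of these compounds alone.

Compound 2 `N=C(NCCCc1c[nH]cn1)NCCC(c1cc(F)cc(F)c1)c1ccccn1`: 275 nM
Compound 1 `N=C(NCCCc1c[nH]cn1)NCCC(c1ccc(F)c(F)c1)c1ccccn1`: 85.1 nM

In a functional assay on ileum for antagonist activity at histamine H1 receptor (Cavia porcellus) (a higher number here means weaker binding, a lower number tighter binding), compound 2 gives the highest of the two numbers; its nearest neighbour is compound 1 at 85.1 nM, and the step of a 3.2-fold higher number from compound 1 to compound 2 (0.51 log units; beyond the scatter) is the only one measured. Compound 3 `N=C(NCCCc1c[nH]cn1)NCCC(c1ccccn1)c1cccs1` arises from compound 2 through (thiophen-2-yl in place of 3,5-difluorophenyl on a saturated chain carbon bound to an aromatic carbon and a saturated chain carbon). For the measured compounds named here, no measured step bears on this change, so the expectation is loosely guided only by the modest size of a 3.2-fold higher number from compound 1 to compound 2 (0.51 log units; beyond the scatter). Compound 3 is therefore expected to give 150 nM, ranging from 40 nM to 600 nM, an estimated step of a 1.8-fold lower number from compound 2 to compound 3 (0.26 log units; within the scatter).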

Compound 3, dissociation constant: 45.7 nM
Compound 3: the middle estimate sits 3.3-fold (0.52 log units) above what was measured; the range from low to high includes it.
By their numbers in this assay, from the lowest: compounds 3 and 1 (each within the scatter of the next); then compound 2.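

In this assay, the step of a 6.0-fold lower number from compound 2 to compound 3 (0.78 log units; beyond the scatter) shows that the five-membered thiophen-2-yl is tolerated on this saturated chain carbon, while the step of a 1.9-fold lower number from compound 1 to compound 3 (0.27 log units; within the scatter) places it level with the 3,4-difluorophenyl. This position therefore needs neither fluorine nor a six-membered carbon ring to reach the number of compound 1, and among these three groups only the 3,5-difluorophenyl stands apart. Nothing available explains this difference between the groups.

As far as these compounds go, whether thiophen-3-yl, furan-2-yl or plain phenyl would serve equally at this carbon remains open. So does the effect of a chlorine atom on the thiophen-2-yl.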